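A Second Fluoro on the 3-Fluorophenyl Group

The compounds below may be only part of what the source reports. "The series", "measured", "known", "first", "only" and "open" are said of these compounds alone.

compound 1 `Cc1cc(=O)n(-c2ccccc2OC(F)(F)F)nc1C(=O)Nc1ccc(Oc2ncnc3sccc23)c(F)c1`: in a functional assay on MCF7 cells (Homo sapiens) for cytotoxicity, read by MTT assay, with a stated time of 72 h (on this read-out higher numbers stand for weaker inhibition and lower numbers for stronger inhibition), compound 1 reaches only a limit of > 40000 nM.
compound 2 `Cc1cc(=O)n(-c2cccc(F)c2)nc1C(=O)Nc1ccc(Oc2ncnc3sccc23)c(F)c1`: in this assay compound 2 gives 17300 nM.

Compound 2 holds the only number shown; the other value is a limit. The measured step of an at least 2.3-fold lower number from compound 1 to compound 2 (0.36 log units; beyond the scatter); it bears on (the limit of > 40000 nM in this assay, at which 1 of the 2 values shown sits). Compound 3 `Cc1cc(=O)n(-c2ccc(F)c(F)c2)nc1C(=O)Nc1ccc(Oc2ncnc3sccc23)c(F)c1` differs from compound 2 by fluoro in place of hydrogen on an aromatic carbon. Among the measured compounds shown here, no measured step adds a single fluoro to this ring, so the step is expected to stay within the scatter: a 1.2-fold lower number from compound 2 to compound 3 (0.06 log units; within the scatter). Compound 3 is therefore estimated at 15000 nM, with a range from 5000 nM to 40000 nM.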

Compound 3, half-maximal inhibitory concentration: 20600 nM
For compound 3 the middle estimate is 1.4-fold (0.14 log units) below the measured one, within the range that was stated.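

Placing a fluoro on the 3-fluorophenyl group of compound 2 to give the 3,4-difluorophenyl group of compound 3 leaves the number in this assay within the scatter (a 1.2-fold higher number from compound 2 to compound 3 (0.08 log units; within the scatter)). At this position, then, the change shows no readable effect on cytotoxicity. Against the 2-(trifluoromethoxy)phenyl group of compound 1, whose value is a limit, the step (an at least 1.9-fold lower number from compound 1 to compound 3 (0.28 log units; that floor lies within the scatter)) no longer shows a clear gain, and it rests on that limit: the limit of > 40000 nM in this assay, at which 1 of the 3 values shown sits.

Going by these compounds, whether an amine, a methoxy group or a carboxylic acid at this position would move the number beyond the scatter stays open.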